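The source may hold more compounds than are shown below. What is called first, only, known or untested is meant among the compounds shown, and "the series" means these compounds.

Compound 1 `Cc1ccc(-c2n[nH]cc2N2CCCNCC2)cc1` gives in an assay on isolated protein for binding affinity to 5-hydroxytryptamine receptor 4 (Homo sapiens) (a lower number here means a stronger inhibitor, a higher number a weaker inhibitor), the value > 10000 nM; this is a limit of the assay, not a number.
Compound 2 `Clc1ccc(-c2n[nH]cc2N2CCCNCC2)cc1` gives in this assay the value > 10000 nM; this too is a limit.
Compound 3 `Fc1ccc(-c2n[nH]cc2N2CCCNCC2)cc1` gives in this assay the value > 10000 nM; this is again a limit.

Compound 3 therefore stands at the limit of this assay, together with the two other compounds, as the evidence states: the limit of > 10000 nM in this assay, at which 3 of the 3 values shown sit. The step to compound 4 `COc1ccc(-c2n[nH]cc2N2CCCNCC2)cc1` is methoxy in place of fluoro on an aromatic carbon.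

Going by the values given here, three measured steps touch the same aromatic carbon: a step that the two limits leave unreadable from compound 1 to compound 2, a step that the two limits leave unreadable from compound 1 to compound 3 and a step that the two limits leave unreadable from compound 2 to compound 3. None of them has a readable size; both ends of each step sit at the limit. They show only that methyl, chloro and fluoro on that carbon all leave the binding at the limit. Among the compounds with values here, no measured step covers a methoxy entering at this place, so the change from compound 3 to compound 4 rests on no direct precedent.

The step from compound 3 to compound 4 is expected to be a step that the limit leaves unreadable from compound 3 to compound 4, which is to say no readable change. Compound 4 is therefore expected to remain at the limit of this assay, with an estimate of 15000 nM and a range from 3000 nM to 60000 nM.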

Compound 4, inhibition constant: > 10000 nM
Compound 4 was reported as a limit; the forecaster's own chance of this, stated with the estimate: 80%; the middle value does not contradict the limit.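

In this assay compound 4 gives > 10000 nM, which is a limit. Going by these compounds alone, no step from compound 1, compound 2 or compound 3 to compound 4 can be read, as both ends of each are limits. The compounds shown leave open how strongly any of the four binds, and whether any group at this place can bring a readable value.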